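The compounds below may be only part of what the source reports. "The series", "measured", "known", "first", "only" and "open" are said of these compounds alone.

Working notes on the series. Compound 1 `CCN(CC)C(=O)c1c(NC(=O)c2cccs2)sc2c1CCC2` gives 7100 nM in a functional assay on A549 cells (Homo sapiens) for cytotoxicity, with a stated time of 60 h; a lower number here means that less compound is needed, a higher number that more compound is needed for the effect. Compound 3 `CCN(CC)C(=O)c1c(NC(=O)c2cccs2)sc2c1CC(C)C2` differs from compound 1 by methyl in place of hydrogen on a saturated ring carbon; in this assay compound 3 gives 7700 nM, and the step is a 1.1-fold higher number from compound 1 to compound 3 (0.04 log units; within the scatter). Compound 2 `CCN(CC)C(=O)c1c(NC(=O)c2cccs2)sc2c1CCC(C)C2` gives 6100 nM in this assay; the difference between the core of compound 2 and the core of compound 1 is not broken down here, and the values of compound 1, compound 2 and compound 3 all lie within the scatter of one another.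

Compound 4 `CCN(CC)C(=O)c1c(NC(=O)c2cccs2)sc2c1CCC(C)(C)C2` is not yet measured. It differs from compound 2 by methyl in place of hydrogen on a saturated ring carbon. This is the same kind of change as that from compound 1 to compound 3, not the same: in compound 3 the methyl sits on a five-membered non-aromatic ring of carbon only, in compound 4 on a six-membered non-aromatic ring of carbon only, both part of a fused or bridged system of two rings.

Among the compounds with values here, the expected step is a 1.1-fold higher number from compound 2 to compound 4 (0.03 log units; within the scatter), because a 1.1-fold higher number from compound 1 to compound 3 (0.04 log units; within the scatter) is within the scatter and this kind of change is seen only in that one pair. Compound 4 is therefore estimated at 6500 nM in this assay, with a likely range from 3500 nM to 12000 nM.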

Compound 4, half-maximal effective concentration: 24000 nM
The estimate for compound 4 lay 3.7-fold (0.57 log units) below the measured number, and the stated range ends below it.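

In this assay, methyl in place of hydrogen on a saturated ring carbon gives a 3.9-fold higher number from compound 2 to compound 4 (0.59 log units; beyond the scatter), so the step does not carry over at one size from one core to the other: the same change on two cores in this assay, a 1.1-fold higher number (0.04 log units; within the scatter) from compound 1 to compound 3 and a 3.9-fold higher number (0.59 log units; beyond the scatter) from compound 2 to compound 4, 3.6-fold (0.56 log units) apart, beyond the scatter of two such steps

On the core of compound 2, more compound is needed for the effect after this change, whereas on the core of compound 1 the change leaves the number within the scatter. Within the data shown here, with only two pairs, this shows that the step depends on the core, but not which difference between the cores matters: the ring in compound 4 is six-membered and already carries a methyl in compound 2, while the ring in compound 3 is five-membered and carries none in compound 1, and these two differences cannot be separated here.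

The compounds shown leave open whether an ethyl group, a hydroxyl or an amine on the same saturated ring carbon would behave like the added methyl of compound 4. They also leave open what a single methyl does on a six-membered ring that carries no other methyl.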